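A few compounds are considered here, and "the series" means these few. Any claim that something is new, unique, unknown or untested is made for them only; others in the source may bear on it.

In a functional assay on Ehrlich cells (Mus musculus) for antiproliferative activity, read by trypan blue exclusion, with a stated time of 2 h (a higher number here means a weaker inhibitor, a lower number a stronger inhibitor), compound 1 `N#CC1=C(N)N(c2ccc(S(N)(=O)=O)cc2)C2=C(C(=O)CCC2)C1/C=C/c1ccccc1` gives > 100 ug/mL which is a limit of the assay and not a number. Going by the values given here, compound 2 `N#CC1=C(N)N(c2ccc(S(N)(=O)=O)cc2)C2=C(C(=O)CCC2)C1c1ccc(Cl)cc1Cl` gives 25 ug/mL in this assay and is the only compound with an actual number so far. Among the compounds with values here, the one measured step, 2,4-dichlorophenyl in place of 2-phenylethenyl on a saturated ring carbon, is an at least 4.0-fold lower number from compound 1 to compound 2 (0.60 log units; beyond the scatter) and it shows that the group at this place can matter. Within the data shown here, compound 3 `Cc1ccoc1C1C(C#N)=C(N)N(c2ccc(S(N)(=O)=O)cc2)C2=C1C(=O)CCC2` changes the group at that same place again, 3-methylfuran-2-yl in place of 2,4-dichlorophenyl on a saturated ring carbon and no measured step covers a group of this kind. Compound 3 gives up the 2,4-dichlorophenyl of compound 2, which stands at 25 ug/mL in this assay so weaker inhibition is the likelier direction. The expected change is modest, a 2.0-fold higher number from compound 2 to compound 3 (0.30 log units; within the scatter) and it remains uncertain. For compound 3 the estimated value is 50 ug/mL with an expected range from 15 ug/mL to 150 ug/mL.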

Compound 3, half-maximal inhibitory concentration: > 100 ug/mL
Compound 3 was reported as a limit; the forecaster's own chance of this, stated with the estimate: 30%; at least 2.0-fold (0.30 log units) between middle value and limit.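

In this assay, putting 3-methylfuran-2-yl in place of 2,4-dichlorophenyl on this saturated ring carbon gives an at least 4.0-fold higher number from compound 2 to compound 3 (0.60 log units; beyond the scatter). A second replacement of a different kind, a five-membered aromatic ring with an oxygen instead of a six-membered aromatic ring of carbon only, therefore also falls short of the number seen with 2,4-dichlorophenyl, which remains the only group shown here with a measured value. The step from compound 1 to compound 3 cannot be read, because both values are limits: the limit of > 100 ug/mL in this assay, at which 2 of the 3 values shown sit.

As far as these compounds go, it remains open whether the chlorine atoms of compound 2 or its six-membered aromatic ring of carbon matters more at this position. An unsubstituted phenyl group or a 4-chlorophenyl group on the same carbon would help separate the two.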